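Aryl swap on the shared core: compound 3 to compound 4

The compounds below may be only part of what the source reports. "The series", "measured", "known", "first", "only" and "open" are said of these compounds alone.

Compound 3 `CCc1ccc(-c2cn3ccnc3c(-c3ccc4ncn(Cc5ccccc5)c4c3)n2)cc1` stands second highest of the three numbers in a functional assay on OVCAR-8 cells (Homo sapiens) for inhibition, read by sulforhodamine B assay, with a stated time of 48 h, tested at 10 uM; a lower number here means less inhibition, a higher number more inhibition at the concentration tested (going by the name of the read-out): compound 3 gives 30.8%. Its nearest neighbour is compound 2 `Clc1ccc(-c2cn3ccnc3c(-c3ccc4ncn(C5CCCCC5)c4c3)n2)cc1`, which gives 3.78%, a number lower than compound 3 beyond the scatter. Furthest away is compound 1 `c1ccc(-c2cn3ccnc3c(-c3ccc4ncn(C5CCCCC5)c4c3)n2)cc1`, which gives 63.9%, higher than compound 3 beyond the scatter.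

Within the data shown here, only one single-point step is known on the series, a number 60.1 percentage points lower from compound 1 to compound 2 (beyond the scatter), a chloro in place of hydrogen on an aromatic carbon. That step shows how much the number can move when the aryl ring on the shared core is altered.

Compound 4 `c1ccc(Cn2cnc3ccc(-c4nc(-c5cccc6ccccc56)cn5ccnc45)cc32)cc1` differs from compound 3 as follows: naphthalen-1-yl in place of 4-ethylphenyl on an aromatic carbon. The change exchanges the whole six-membered aromatic ring of carbon only for a naphthalen-1-yl, so the measured step, which concerns a substituent on a ring of that kind, bears on it only loosely; its size shows that such alterations can be large, and its direction was downward. A step of moderate size, in either direction, is therefore plausible, and the expected step is a number 2.8 percentage points lower from compound 3 to compound 4 (within the scatter). Compound 4 is estimated at 28%, with a range from 5% to 60%.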

Compound 4, a percentage reported as inhibition, at one concentration (the size of the read-out at that concentration, not a potency): 6.22%
Beside the measured number, compound 4's estimate is 21.8 percentage points above it, and the stated range covers the measured number.
By their numbers in this assay, from the lowest: compounds 2 and 4 (each within the scatter of the next); then compound 3; then compound 1.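

In this assay, the aryl group on the shared core proves sensitive to replacement as a whole, not only to a substituent on its ring: naphthalen-1-yl in place of 4-ethylphenyl gives a number 24.6 percentage points lower from compound 3 to compound 4 (beyond the scatter) and takes the reading to a low level. The counted hydrogen-bond donors, hydrogen-bond acceptors and net charge are the same for both groups, so this step comes with a change from one six-membered aromatic ring of carbon only to two, and from 8 to 10 heavy atoms, and with no change in those counts. With a number 60.1 percentage points lower from compound 1 to compound 2 (beyond the scatter), there are now two single-place steps at this aryl group, on compounds that carry different groups elsewhere, and both go downward, with none against; no measurement shown explains the drop.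

The compounds shown do not separate the loss of the ethyl group from the arrival of the second ring, so a plain phenyl or a 4-methylphenyl on the compound 3 scaffold would be informative. Also open, going by these compounds, is how this position responds to a group of another kind, such as an amine, a carboxylic acid or a longer chain in place of ethyl.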